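Swapping the nitro ring for dimethoxy on a cinnamamide

A few compounds are considered here, and "the series" means these few. Any claim that something is new, unique, unknown or untested is made for them only; others in the source may bear on it.

Measured compounds:
- compound 1, `O=C(/C=C/c1ccc([N+](=O)[O-])cc1)Nc1cc2c(Nc3ccc(F)c(Cl)c3)ncnc2cc1O[C@H]1CCOC1`: 22800 nM
- compound 2, `COc1ccc(/C=C/C(=O)Nc2cc3c(Nc4ccc(F)c(Cl)c4)ncnc3cc2OC)cc1`: "not active" (no number reported)
- compound 3, `COc1cc2ncnc(Nc3ccc(F)c(Cl)c3)c2cc1NC(=O)/C=C/c1ccc(C#N)cc1`: "not active" (no number reported)

Among the measured compounds shown here, in a functional assay on PC-3 cells (Homo sapiens) for cytotoxicity, read by MTT assay, with a stated time of 72 h (on this read-out higher numbers stand for weaker inhibition and lower numbers for stronger inhibition), compound 1 gives 22800 nM, and it is the only compound of the three with a number at all. Compound 2 returns "not active" (no number reported) in this assay, and compound 3 returns "not active" (no number reported) as well, so neither offers a value to compare with. Compound 1 therefore stands alone as the one entry with measurable, though weak, inhibition.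

Compound 4, `COc1cc(/C=C/C(=O)Nc2cc3c(Nc4ccc(F)c(Cl)c4)ncnc3cc2O[C@H]2CCOC2)cc(OC)c1`, keeps the whole core of compound 1 and changes only the ring at the far end of the chain: 3,5-dimethoxyphenyl in place of 4-nitrophenyl on a double-bonded chain carbon bound to a double-bonded chain carbon. For the measured compounds named here, no measured pair shows the effect of such a swap, so the expectation rests on compound 1 alone. The step from compound 1 to compound 4 is expected to be small in this assay, at most a modest drift toward weaker inhibition, a 1.3-fold higher number from compound 1 to compound 4 (0.12 log units; within the scatter). Compound 4 is estimated at 30000 nM in this assay, with a likely range from 10000 nM to 100000 nM.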

Compound 4, half-maximal inhibitory concentration: 25600 nM
Compound 4: the middle estimate sits 1.2-fold (0.07 log units) above what was measured; measured number inside the range.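

In this assay, among the compounds shown here, the swap of 4-nitrophenyl for 3,5-dimethoxyphenyl on a double-bonded chain carbon bound to a double-bonded chain carbon gives a 1.1-fold higher number from compound 1 to compound 4 (0.05 log units; within the scatter) and is the first measured change at this place. The two rings cannot be told apart in this read-out, even though they are different groups, so on the core of compound 1 the nitro group is not needed for a measurable number. Nothing available on these compounds speaks to the reason for this result.

Still open, from the compounds shown here alone, is whether an amine or a carboxylic acid on this ring, or a longer chain carrying it, would move the number beyond the usual scatter. An unsubstituted phenyl ring at this place also remains to be compared with these two rings.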